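The source may report more compounds than this note shows. Statements on the series, on what has been measured and on what is new or still open speak of the compounds shown alone.

In a functional assay on the whole organism with Mus musculus as the target (a higher number here means that more compound is needed for the effect, a lower number that less compound is needed), compound 1 `OC1CCN(c2ccc(-c3ccccc3Cl)nn2)CC1` gives 38 mg/kg, the second highest of three numbers. Compound 2 `OC1CCN(c2ccc(-c3ccccc3F)nn2)CC1` gives 30 mg/kg and compound 3 `Cc1ccccc1-c1ccc(N2CCC(O)CC2)nn1` gives 40 mg/kg; the steps of a 1.3-fold lower number from compound 1 to compound 2 (0.10 log units; within the scatter) and a 1.1-fold higher number from compound 1 to compound 3 (0.02 log units; within the scatter) both fall within the scatter, so the three numbers cannot be told apart. Compound 4 `CCCC(=O)OC1CCN(c2ccc(-c3ccccc3Cl)nn2)CC1` is compound 1 with propylcarbonyl in place of hydrogen on an oxygen on a saturated carbon. Among the compounds with values here, every measured step exchanges one group on an aromatic carbon; none touches the oxygen on the saturated carbon, so no measured step bears on this change, and there is no basis for expecting a shift beyond the scatter in this assay in either direction. The estimate for compound 4 is therefore 42 mg/kg, with a range from 18 mg/kg to 100 mg/kg, a step of a 1.1-fold higher number from compound 1 to compound 4 (0.04 log units; within the scatter) that is expected to stay within the scatter.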

Compound 4, dose for half-maximal effect: 39 mg/kg
The estimate for compound 4 lay 1.1-fold (0.03 log units) above the measured number, within the range that was stated.
By their numbers in this assay, from the lowest: compounds 2, 1, 4 and 3 (each within the scatter of the next).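

Within the data shown here, the earlier steps all exchanged a group on an aromatic carbon, so this is the first reading at the oxygen on a saturated carbon. In this assay, the change from hydroxy to (propylcarbonyl)oxy is a step of a 1.0-fold higher number from compound 1 to compound 4 (0.01 log units; within the scatter), so this position accepts propylcarbonyl, with its 5 heavy atoms, without a shift that can be told from the scatter. No measurement shown here explains this result. Still open, from the compounds shown here alone, is whether a longer chain on this oxygen would also leave the number within the scatter. An amine in place of the hydroxy is equally untested among these compounds.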